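The source may report more compounds than this note shows. Statements on the series, on what has been measured and on what is new or still open speak of the compounds shown alone.

In a functional assay on K562 cells (Homo sapiens) for inhibition, read by MTT assay, with a stated time of 48 h (on this read-out higher numbers stand for weaker inhibition and lower numbers for stronger inhibition), compound 3 `CCCC(=O)OCCCOC(=O)c1ccc(C(=O)Nc2ccc3c(c2)C(C)(C)CCC3(C)C)cc1` gives 4570 nM, the lowest of the two numbers reported. Compound 2 `CCCC(=O)OCCOC(=O)c1ccc(C(=O)Nc2ccc3c(c2)C(C)(C)CCC3(C)C)cc1` gives 18600 nM, and the step of a 4.1-fold lower number from compound 2 to compound 3 (0.61 log units; beyond the scatter) lies beyond the scatter. Compound 1 `CCCC(CCC)C(=O)OCCCCOC(=O)c1ccc(C(=O)Nc2ccc3c(c2)C(C)(C)CCC3(C)C)cc1` reaches only > 1000000 nM, which is a limit of the assay and not a number. Compound 4 `CCCC(CCC)C(=O)OCCCOC(=O)c1ccc(C(=O)Nc2ccc3c(c2)C(C)(C)CCC3(C)C)cc1` differs from compound 3 by 1-propylbutyl in place of propyl on a carbonyl carbon. Among the compounds with values here, no measured step isolates this change: the steps of an at least 210-fold lower number from compound 1 to compound 3 (2.34 log units; beyond the scatter) and an at least 53-fold lower number from compound 1 to compound 2 (1.73 log units; beyond the scatter) each combine it with a second change, so they bear on it only in part. Because both an at least 210-fold lower number from compound 1 to compound 3 (2.34 log units; beyond the scatter) and an at least 53-fold lower number from compound 1 to compound 2 (1.73 log units; beyond the scatter) were large, compound 4 is expected to give a higher number, estimated at 50000 nM with a range of 8000 nM to 500000 nM, an expected step of an 11-fold higher number from compound 3 to compound 4 (1.04 log units; beyond the scatter).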

Compound 4, half-maximal inhibitory concentration: > 1000000 nM
Compound 4: no number, only a limit; the forecaster's own chance of this, stated with the estimate: 25%; middle value at least 20-fold (1.30 log units) away from the limit.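

In this assay, within the data shown here, the step of an at least 210-fold higher number from compound 3 to compound 4 (2.34 log units; beyond the scatter) is the first to isolate 1-propylbutyl in place of propyl on a carbonyl carbon, and it is large. The step of an at least 53-fold higher number from compound 2 to compound 4 (1.73 log units; beyond the scatter) is also large, although it changes the chain as well. The branched group now gives the same picture with two different chain lengths: the same change on two cores in this assay, an at least 210-fold lower number (2.34 log units; beyond the scatter) from compound 1 to compound 3 and an at least 53-fold lower number (1.73 log units; beyond the scatter) from compound 4 to compound 2; the limit leaves it open whether they differ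

The step between compound 1 and compound 4 cannot be read, as both values are limits. Going by these compounds, how a butyl or isopropyl group at this carbonyl carbon would behave remains open.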